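The compounds below may be only part of what the source reports. "The series", "measured", "known", "first", "only" and "open" are said of these compounds alone.

Working notes on the series.

Of the compounds shown here, two carry numbers so far. Compound 1 `COC(=O)[C@@]1(C)CCC=C2[C@@H]1CC[C@@H](C)[C@]2(C)Cc1c[nH]c2ccc(Cl)cc12` in a functional assay on HeLa cells (Homo sapiens) for inhibition, read by sulforhodamine B assay, with a stated time of 48 h (on this read-out lower numbers stand for stronger inhibition of growth and higher numbers for weaker inhibition of growth), gives 11000 nM. Compound 2 `COC(=O)[C@@]1(C)CC[C@@H]2C3=C1CC[C@@H](C)[C@]3(C)Cc1c2[nH]c2ccccc12` in this assay gives 3200 nM, the lower of the two numbers, and the gap to compound 1 lies beyond the scatter.

Compound 3 `COC(=O)[C@@]1(C)CC[C@@H]2C3=C1CC[C@@H](C)[C@]3(C)Cc1c2[nH]c2ccc(OC)cc12` is not yet measured. It differs from compound 2 in one place: methoxy in place of hydrogen on an aromatic carbon. Within the data shown here, no pair of measured compounds shows this change, so nothing in the numbers at hand tells which way it should run; the only substituted ring in the set, in compound 1, sits on a different core and gives no guide. The step from compound 2 to compound 3 is therefore expected to stay within the scatter, with a 1.3-fold higher number from compound 2 to compound 3 (0.10 log units; within the scatter) as the working assumption. For compound 3 in this assay the estimate is 4000 nM, within a range from 1500 nM to 11000 nM.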

Compound 3, concentration for 50% growth inhibition: 3900 nM
Beside the measured number, compound 3's estimate is 1.0-fold (0.01 log units) above it; low and high end bracket the measured number.
By their numbers in this assay, from the lowest: compounds 2 and 3 (each within the scatter of the next); then compound 1.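

Methoxy in place of hydrogen on an aromatic carbon is the first change that can be read on the shared core: in this assay it gives a 1.2-fold higher number from compound 2 to compound 3 (0.09 log units; within the scatter). The aromatic carbon meta to a fused ring and para to a fused ring therefore takes methoxy, with its added oxygen and carbon, without a shift beyond the scatter, something compound 1 and compound 2 alone could not show. No measurement at hand bears on why the number holds with this group in place.

Only hydrogen and methoxy are shown on this aromatic carbon, so one step cannot show whether the insensitivity extends to other groups. On these data alone, whether a hydroxyl, an amine, a carboxylic acid or a longer alkoxy chain at this carbon would move the number beyond the scatter remains open.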